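This account rests on a few compounds, and the source may have more. Where it says the series, first, only, none or still open, it means among the compounds named here.

Compound 1, `CCn1cc(-c2ccnc(Nc3ccc(OC)cc3OC)n2)c2ccccc21`, gives 430 nM in an assay for inhibition of MAP kinase-interacting serine/threonine-protein kinase 2 (Homo sapiens), read by TR-FRET; a higher number here means a weaker inhibitor, a lower number a stronger inhibitor.
Compound 2, `CNc1nc(C)c(-c2ccnc(Nc3ccc(OC)cc3OC)n2)s1`, gives 110 nM in this assay.

Of these two numbers, compound 1 holds the higher one; its value sits well apart from that of compound 2, so compound 1 is the weaker inhibitor of the pair in this assay. Among the measured compounds shown here, compound 3, `COc1ccc(Nc2nccc(-c3cn(C4CCCC4)c4ccccc34)n2)c(OC)c1`, keeps the core of compound 1 and changes only one group: cyclopentyl in place of ethyl on an aromatic nitrogen. For the measured compounds named here, no measured pair shows what this particular exchange does, so the expectation rests on the starting value of compound 1 alone. A larger ring in place of a short chain at this position is expected to lower the number somewhat, giving a step from compound 1 to compound 3 of about a 1.7-fold lower number from compound 1 to compound 3 (0.24 log units; within the scatter) in this assay. On that basis compound 3 is estimated at 250 nM in this assay, within a range of 80 nM to 800 nM.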

Compound 3, inhibition constant: 390 nM
Compound 3: middle estimate off by 1.6-fold (0.19 log units), on the low side; the measured number falls inside the stated range.
By their numbers in this assay, from the lowest: compound 2; then compounds 3 and 1 (each within the scatter of the next).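

Putting cyclopentyl in place of ethyl on an aromatic nitrogen gives a 1.1-fold lower number from compound 1 to compound 3 (0.04 log units; within the scatter) in this assay, so the two compounds cannot be told apart here. Among the compounds shown here, at this position, then, the larger group with its five-membered non-aromatic ring of carbon leaves the number within the scatter, which is the first direct reading of a change at this place. Nothing measured here offers a reason for this result.

From the compounds shown here alone, it remains open whether a longer chain, a phenyl ring, or a chain ending in an amine or a carboxylic acid on this nitrogen would move the number beyond the scatter. Also open, going by these compounds, is what a plain hydrogen on this nitrogen would give, which would show whether any group is needed there.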